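Sulfonylacetic acid series: pyrrolyl in place of trifluoromethylphenyl

The source may report more compounds than this note shows. Statements on the series, on what has been measured and on what is new or still open speak of the compounds shown alone.

Measured so far in a functional assay on CHO cells for agonist activity at Free fatty acid receptor 1 (Homo sapiens), read by FLIPR and calcium flux; a lower number here means that less compound is needed, a higher number that more compound is needed for the effect:
Compound 1 `O=C(O)CS(=O)(=O)c1ccc(OCc2cccc(-c3ccccc3C(F)(F)F)c2)cc1` gives 52.5 nM.
Compound 2 `Cc1ccccc1-c1ccc(COc2cccc(S(=O)(=O)CC(=O)O)c2)cc1` gives > 1000 nM, which is a limit of the assay, not a number.
Compound 3 `Cc1nc(-c2cccc(F)c2)sc1COc1ccc(S(=O)(=O)CC(=O)O)cc1` gives 275 nM.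

Compound 1 holds the lowest of the two numbers in this assay; compound 3 sits higher, beyond the scatter. One value sits at the limit of > 1000 nM in this assay, at which 1 of the 3 values shown sits.

Compound 4 `Cc1ccc(C)n1-c1cccc(COc2ccc(S(=O)(=O)CC(=O)O)cc2)c1` differs from compound 1 by 2,5-dimethyl-1H-pyrrol-1-yl in place of 2-(trifluoromethyl)phenyl on an aromatic carbon. Within the data shown here, no measured step of this kind exists in the set. The expectation is a moderate rise in the number, beyond the scatter, roughly a 4.2-fold higher number from compound 1 to compound 4 (0.62 log units; beyond the scatter). Compound 4 is estimated at 220 nM, within 60 nM to 900 nM.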

Compound 4, half-maximal effective concentration: 129 nM
For compound 4 the middle estimate is 1.7-fold (0.23 log units) above the measured one, and the stated range covers the measured number.
By their numbers in this assay, from the lowest: compound 1; then compound 4; then compound 3. At a limit, above all of these: compound 2.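

On this aromatic carbon, 2,5-dimethyl-1H-pyrrol-1-yl in place of 2-(trifluoromethyl)phenyl gives a 2.5-fold higher number from compound 1 to compound 4 (0.39 log units; beyond the scatter) in this assay. The step is modest, so this position accepts a five-membered aromatic ring with a hetero atom, although 2-(trifluoromethyl)phenyl keeps the lower number. Nothing measured here accounts for the step.

As far as these compounds go, whether the rise follows from the ring itself or from its two methyl groups stays open. Also open, from the compounds shown here alone, is what a pyrrol-1-yl ring without methyl groups, or a phenyl ring carrying a nitrile or an amine, would give at this position.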